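This account rests on a few compounds, and the source may have more. Where it says the series, first, only, none or still open, it means among the compounds named here.

Measured so far:
compound 1 `Cc1ccc(/C=N/NC(=O)CSc2nnc(-c3ccncc3)o2)cc1` gives 185000 nM in an ADME assay on NIH3T3 cells (Mus musculus) for cytotoxicity, read by MTT assay, with a stated time of 24 h; on this read-out higher numbers stand for weaker inhibition and lower numbers for stronger inhibition;
compound 2 `O=C(CSc1nnc(-c2ccncc2)o1)N/N=C/c1cc(Cl)cc(Cl)c1O` gives 171000 nM in this assay.

Going by the values given here, compound 2 holds the lowest of the two numbers, with compound 1 its only neighbour at a 1.1-fold lower number from compound 1 to compound 2 (0.03 log units; within the scatter), a gap that lies within the scatter. Compound 3 `O=C(CSc1nnc(-c2ccncc2)o1)N/N=C/c1cc(Br)cc(Br)c1O` differs from compound 2 by 3,5-dibromo-2-hydroxyphenyl in place of 3,5-dichloro-2-hydroxyphenyl on a carbon with a double bond to nitrogen. Among the compounds with values here, no measured step touches this exchange of halogen: the only step known, from compound 1 to compound 2, concerns a different ring and was itself within the scatter, so it gives no direction. On this basis the step of a 1.1-fold lower number from compound 2 to compound 3 (0.06 log units; within the scatter) is expected to stay within the scatter. Compound 3 is therefore estimated at 150000 nM in this assay, with a range from 60000 nM to 350000 nM.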

Compound 3, half-maximal inhibitory concentration: 190000 nM
Compound 3: the middle estimate sits 1.3-fold (0.10 log units) below what was measured; the measured number falls inside the stated range.
By their numbers in this assay, from the lowest: compounds 2, 1 and 3 (each within the scatter of the next).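

The step from chlorine to bromine on the ring is the new information at this position: in this assay it gives a 1.1-fold higher number from compound 2 to compound 3 (0.05 log units; within the scatter), so exchanging 3,5-dichloro-2-hydroxyphenyl for 3,5-dibromo-2-hydroxyphenyl leaves no readable difference. The comparison with the 4-methylphenyl group gives a 1.0-fold higher number from compound 1 to compound 3 (0.01 log units; within the scatter), so the dibromo group, like the dichloro group before it, stands level with that group on a carbon with a double bond to nitrogen. Nothing available explains this result.

As far as these compounds go, all three compounds carry a six-membered aromatic ring of carbon only at this place, so it remains open whether any group here can move the number beyond the scatter. A ring bearing an amine or a carboxylic acid, or a longer chain in place of the ring, could test this.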